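Notes on a thiourea-linked anilide series: change at the aryl carbon

This account rests on a few compounds, and the source may have more. Where it says the series, first, only, none or still open, it means among the compounds named here.

Measured compounds:
compound 1 `CC1=C(C(=O)Nc2ccc(Cl)c(Cl)c2)C(c2cccc(O)c2)NC(=S)N1`, 13500 nM
compound 2 `CC1=C(C(=O)Nc2ccc(Cl)c(Cl)c2)C(c2cccc(Oc3ccccc3)c2)NC(=S)N1`, 13200 nM
compound 3 `CC1=C(C(=O)Nc2ccc(F)c(Cl)c2)C(c2cccc(Oc3ccccc3)c2)NC(=O)N1`, 40700 nM

In a functional assay on HOP-92 cells (Homo sapiens) for cytotoxicity, read by sulforhodamine B assay, with a stated time of 48 h (a higher number here means a weaker inhibitor of growth, a lower number a stronger inhibitor of growth), compound 1 gives 13500 nM, the second highest of the three numbers; compound 2 sits at 13200 nM, within the scatter of it, while compound 3 at 40700 nM lies beyond the scatter above it. Compound 4 `CC1=C(C(=O)Nc2ccc(Cl)c(Cl)c2)C(c2ccccc2Cl)NC(=S)N1` differs from compound 1 by 2-chlorophenyl in place of 3-hydroxyphenyl on a saturated ring carbon. Going by the values given here, the only step at that position is a 1.0-fold lower number from compound 1 to compound 2 (0.01 log units; within the scatter), where a phenyl replaced the hydroxyl hydrogen without effect. Among the compounds with values here, no step exchanges the whole aryl group, so the expectation for compound 4 in this assay rests on that one flat step and is no change beyond the scatter. Compound 4 is therefore estimated at 13000 nM (range 5000 nM to 35000 nM), an expected step of a 1.0-fold lower number from compound 1 to compound 4 (0.02 log units; within the scatter).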

Compound 4, concentration for 50% growth inhibition: 1200 nM
Compound 4: the middle estimate sits 11-fold (1.03 log units) above what was measured, and the stated range ends above it.
By their numbers in this assay, from the lowest: compound 4; then compounds 2 and 1 (each within the scatter of the next); then compound 3.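

In this assay the saturated ring carbon is sensitive to the aryl group: replacing the whole group gives an 11-fold lower number from compound 1 to compound 4 (1.05 log units; beyond the scatter) and contrasts with a 1.0-fold lower number from compound 1 to compound 2 (0.01 log units; within the scatter) at the hydroxyl oxygen. Compound 4 loses the hydroxyl and gains the chlorine in one change, so the two cannot be separated here. No measured evidence bears on the cause of this step.

Open, on these data alone, is whether the chlorine alone carries the step. Unsubstituted phenyl, 3-chlorophenyl and 2-methoxyphenyl on the same carbon would separate the substituent's identity from its place on the aryl ring.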